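Removing a Hydroxy Group from a Chalcone Growth Inhibitor

The source may report more compounds than this note shows. Statements on the series, on what has been measured and on what is new or still open speak of the compounds shown alone.

Compound 1, `COc1cc(C(=O)/C=C/c2ccc(O)c(O)c2)cc(OC)c1OC`: 2600 nM
Compound 2, `COc1ccc(/C=C/C(=O)c2cc(OC)c(O)c(OC)c2)cc1O`: 4000 nM
Compound 3, `COc1ccc(/C=C/C(=O)c2cc(OC)c(OC)c(OC)c2)cc1OCCO`: 4700 nM

These three compounds were tested in a functional assay on A549 cells (Homo sapiens) for cytotoxicity, read by fluorescence, with a stated time of 48 h; on this read-out lower numbers stand for stronger inhibition of growth and higher numbers for weaker inhibition of growth. Compound 1 gives the lowest of the three numbers, yet its gaps to compound 2 and to compound 3 both fall within the usual scatter of this assay, so none of the three can be set apart from the others. Compound 4, `COc1cc(C(=O)/C=C/c2ccc(O)cc2)cc(OC)c1OC`, has not yet been tested. It differs from compound 1 in one place: hydrogen in place of hydroxy on an aromatic carbon. Among the compounds with values here, no measured pair shows what this change does here, so the expectation rests on compound 1 alone. The step of a 1.5-fold higher number from compound 1 to compound 4 (0.19 log units; within the scatter) is expected to be small, towards weaker growth inhibition, and probably not beyond the scatter. Compound 4 is estimated at 4000 nM, within a range from 1500 nM to 12000 nM.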

Compound 4, concentration for 50% growth inhibition: 8500 nM
Compound 4: the middle estimate sits 2.1-fold (0.33 log units) below what was measured; the range from low to high includes it.
By their numbers in this assay, from the lowest: compounds 1, 2, 3 and 4 (each within the scatter of the next, the first and the last beyond it).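

Going from 3,4-dihydroxyphenyl to 4-hydroxyphenyl gives a 3.3-fold higher number from compound 1 to compound 4 (0.51 log units; beyond the scatter), so replacing this hydroxy group with hydrogen weakens growth inhibition. Unlike the gaps among the first three compounds, this step lies beyond the scatter, which shows that the hydroxy group at this position counts in compound 1. Nothing available here explains why the loss occurs. Still open, going by these compounds, is whether another group at this place, such as an amine or a fluorine atom, would keep the growth inhibition of compound 1 or lose it as hydrogen does.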